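The source may hold more compounds than are shown below. What is called first, only, known or untested is meant among the compounds shown, and "the series" means these compounds.

Measured so far:
compound 1 `CCc1cc(S(=O)(=O)N2C[C@H](c3ccccc3)NC2=O)ccc1NC(=O)c1ccc(N)cc1` — 670 nM
compound 2 `Cc1cc(S(=O)(=O)N2C(=O)N[C@@H](c3ccccc3)C2C)ccc1NC(=O)c1ccc([N+](=O)[O-])cc1` — > 10000 nM
compound 3 `CCOC(=O)Nc1ccc(S(=O)(=O)N2C[C@H](c3ccccc3)NC2=O)cc1C` — 70 nM

All three were tested in a functional assay on NCI-H460 cells (Homo sapiens) for cytotoxicity, read by MTT assay (on this read-out lower numbers stand for stronger inhibition and higher numbers for weaker inhibition), which reports the concentration of a compound at which the growth of the lung cancer cells is inhibited. Compound 1 gives 670 nM, the higher of the two numbers reported, so it is the weaker of the two measured cytotoxic agents. Compound 3 gives 70 nM. For compound 2 this assay reports only a limit, > 10000 nM, not a number. Compound 2 sits at the limit of > 10000 nM in this assay, at which 1 of the 3 values shown sits.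

The next compound, compound 4 `CCc1cc(S(=O)(=O)N2C[C@H](c3ccccc3)NC2=O)ccc1NC(=O)OC`, differs from compound 1 in one place: methoxy in place of 4-aminophenyl on a carbonyl carbon. The resulting structure comes close to that of compound 3. A clear drop in the number from compound 1 is therefore expected, the step of a 5.6-fold lower number from compound 1 to compound 4 (0.75 log units; beyond the scatter) going well beyond the usual scatter, because compound 3 gives 70 nM. Compound 4 is estimated at 120 nM, most likely between 40 nM and 400 nM.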

Compound 4, half-maximal inhibitory concentration: 300 nM
The estimate for compound 4 lay 2.5-fold (0.40 log units) below the measured number; the measured number falls inside the stated range.
By their numbers in this assay, from the lowest: compound 3; then compound 4; then compound 1. At a limit, above all of these: compound 2.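

For the compounds shown here, this is the first pair of measured compounds that differ in one place, so this position can now be read directly: with methoxy in place of 4-aminophenyl on a carbonyl carbon, this assay shows a 2.2-fold lower number from compound 1 to compound 4 (0.35 log units; beyond the scatter) and so a real, if modest, gain. In this pair, the six-membered aromatic ring on the carbonyl carbon is not needed for cytotoxicity, and the smaller methoxy, which has no ring, does somewhat better. Nothing measured here explains why the number falls.

The compounds shown leave open whether the amine of the 4-aminophenyl group matters on its own, which a plain phenyl on the same carbonyl carbon would test. They also leave open how a longer chain such as butoxy, or a dimethylamino group, would behave at this place.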